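Replacing pyridin-2-yl with cyclopentyl on the amide nitrogen

This account rests on a few compounds, and the source may have more. Where it says the series, first, only, none or still open, it means among the compounds named here.

Going by the values given here, compound 3 `C#CCn1cc(C(=O)NC(CC(=O)Nc2ccccn2)c2ccccc2)c(=O)c2cc(F)c(Cl)nc21` gives 2300 nM in a functional assay on KB cells (Homo sapiens) for cytotoxicity, read by MTT assay, with a stated time of 72 h (a lower number here means a stronger inhibitor, a higher number a weaker inhibitor), the only definite number among the three measured compounds. Compound 1 `C#CCn1cc(C(=O)NC(CC(=O)NC2CCCCC2)c2ccccc2)c(=O)c2cc(F)c(Cl)nc21` reaches only the assay limit of > 10000 nM in this assay. Compound 2 `C#CCn1cc(C(=O)NC(CC(=O)NC2CCCC2)c2ccccc2)c(=O)c2ccc(Cl)nc21` likewise sits at the limit of > 10000 nM. Compound 4 `C#CCn1cc(C(=O)NC(CC(=O)NC2CCCC2)c2ccccc2)c(=O)c2cc(F)c(Cl)nc21` differs from compound 3 by cyclopentyl in place of pyridin-2-yl on an amide-type nitrogen. Among the compounds with values here, the one measured step at this position, an at least 4.3-fold lower number from compound 1 to compound 3 (0.63 log units; beyond the scatter), ran the other way, from a saturated ring to pyridin-2-yl, and carried the number away from the limit of > 10000 nM in this assay, at which 2 of the 3 values shown sit. Compound 2, which also bears cyclopentyl, rests at that same limit. Compound 4 is therefore expected to lose potency, with an expected step of a 5.2-fold higher number from compound 3 to compound 4 (0.72 log units; beyond the scatter), most likely back to the limit. The estimate for compound 4 is 12000 nM, within 3000 nM to 40000 nM.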

Compound 4, half-maximal inhibitory concentration: 4900 nM
The estimate for compound 4 lay 2.4-fold (0.39 log units) above the measured number, within the range that was stated.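

In this assay the change to cyclopentyl costs only modestly, with a 2.1-fold higher number from compound 3 to compound 4 (0.33 log units; beyond the scatter), so pyridin-2-yl is not needed for a definite number at this position. The steps of an at least 2.0-fold lower number from compound 1 to compound 4 (0.30 log units; that floor lies within the scatter) and an at least 2.0-fold lower number from compound 2 to compound 4 (0.30 log units; that floor lies within the scatter) give only floors, so the worth of cyclopentyl in place of cyclohexyl and of fluoro in place of hydrogen stays unsized. A saturated ring on this amide nitrogen therefore does not by itself hold a compound at the limit: the limit of > 10000 nM in this assay, at which 2 of the 4 values shown sit.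

The compounds shown leave open how phenyl or an open-chain isopropyl group on this nitrogen would compare. They also leave open whether any group here gives a lower number than compound 3 does.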